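From 3-azidopropyl to vinyl on a shared core

A few compounds are considered here, and "the series" means these few. Any claim that something is new, unique, unknown or untested is made for them only; others in the source may bear on it.

Among the compounds with values here, in a functional assay on P388 cells (Mus musculus) for cytotoxicity (a lower number here means a stronger inhibitor, a higher number a weaker inhibitor), compound 2 `COc1ccc(C[C@H]2C(=O)N[C@@H](C)C(=O)N(C)[C@H]3Cc4ccc(cc4)Oc4cc(ccc4OC)C[C@@H](C(=O)N[C@H](C)C(=O)N[C@@H](CCCN=[N+]=[N-])C(=O)N2C)N(C)C3=O)cc1` gives 35.5 nM and stands lowest of the two numbers so far, with compound 1 `COc1ccc(C[C@H]2C(=O)N[C@@H](C)C(=O)N(C)[C@H]3Cc4ccc(cc4)Oc4cc(ccc4OC)C[C@@H](C(=O)N[C@H](C)C(=O)N[C@@H](CCCCO)C(=O)N2C)N(C)C3=O)cc1` higher at 219 nM in the same test. Compound 3 `C=C[C@@H]1NC(=O)[C@@H](C)NC(=O)[C@@H]2Cc3ccc(OC)c(c3)Oc3ccc(cc3)C[C@@H](C(=O)N2C)N(C)C(=O)[C@H](C)NC(=O)[C@H](Cc2ccc(OC)cc2)N(C)C1=O` carries vinyl in place of 3-azidopropyl on a saturated ring carbon and keeps the rest of the core. Within the data shown here, the one measured step of a 6.2-fold lower number from compound 1 to compound 2 (0.79 log units; beyond the scatter) lies beyond the scatter but changed only the chain end, so it is a loose guide to replacing the whole chain. A step no larger than that one is expected in this assay with a slight lean towards a higher number. The expected step of a 1.7-fold higher number from compound 2 to compound 3 (0.23 log units; within the scatter) is only an estimate. Compound 3 is expected at 60 nM with 15 nM to 240 nM as its estimated range.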

Compound 3, half-maximal inhibitory concentration: 25.7 nM
Compound 3: middle estimate off by 2.3-fold (0.37 log units), on the high side; the range from low to high includes it.
By their numbers in this assay, from the lowest: compounds 3 and 2 (each within the scatter of the next); then compound 1.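

In this assay, replacing 3-azidopropyl with the much shorter vinyl gives a 1.4-fold lower number from compound 2 to compound 3 (0.14 log units; within the scatter) at this saturated ring carbon, so the full length of the azide chain is not required to keep this level of cytotoxicity. Vinyl in place of 4-hydroxybutyl gives an 8.5-fold lower number from compound 1 to compound 3 (0.93 log units; beyond the scatter) and so sets the hydroxyl-ended chain apart from the other two groups. Nothing measured here explains these differences. 

Still open, from the compounds shown here alone, is whether ethyl, with no double bond, would match vinyl at this carbon. Chains ending in an amine or a carboxylic acid are also untested among the compounds shown.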